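The source may report more compounds than this note shows. Statements on the series, on what has been measured and on what is new or still open speak of the compounds shown alone.

Of the three measured compounds, compound 1 `CC(C)C(=O)N1C[C@@H](C)N(c2ncc3[nH]nc(-c4ccc(N5CCN[C@H](C)C5)nc4)c3n2)[C@@H](C)C1` gives in an assay on Sf9 cells for inhibition of activin receptor type-1 (Homo sapiens), read by HTRF, with a stated time of 3 h, in the presence of a further agent that is not named here (a higher number here means a weaker inhibitor, a lower number a stronger inhibitor), 8 nM. Compound 2 `C[C@@H]1CN(c2ccc(-c3n[nH]c4cnc(N5[C@H](C)COC[C@@H]5C)nc34)cn2)CCN1` gives in this assay 23 nM, and compound 3 `C[C@@H]1CN(c2ccc(-c3n[nH]c4cnc(N5CCCCC5)nc34)cn2)CCN1` gives 40 nM. Compound 1 thus stands at the lowest number, with its gaps to compound 2 and compound 3 both beyond the scatter, so it is the strongest inhibitor of the three. Among the compounds with values here, the only one-place step measured, a 1.7-fold higher number from compound 2 to compound 3 (0.24 log units; within the scatter), concerns the group on the aromatic carbon, not the carbonyl.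

Compound 4 `COC(=O)N1C[C@@H](C)N(c2ncc3[nH]nc(-c4ccc(N5CCN[C@H](C)C5)nc4)c3n2)[C@@H](C)C1` differs from compound 1 by methoxy in place of isopropyl on a carbonyl carbon. Within the data shown here, no measured step touches the carbonyl carbon, so nothing in the data predicts a move beyond the scatter. Compound 4 is expected to give 10 nM, in the range 4 nM to 25 nM. This estimate means a step of a 1.3-fold higher number from compound 1 to compound 4 (0.10 log units; within the scatter), expected to lie within the scatter.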

Compound 4, half-maximal inhibitory concentration: 0.85 nM
For compound 4 the middle estimate is 12-fold (1.07 log units) above the measured one; the measured number lies below the stated range.
By their numbers in this assay, from the lowest: compound 4; then compound 1; then compounds 2 and 3 (each within the scatter of the next).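

Within the data shown here, the carbonyl carbon of compound 1 proves to be a position that responds strongly in this assay: methoxy in place of isopropyl gives a 9.4-fold lower number from compound 1 to compound 4 (0.97 log units; beyond the scatter) and is the first measured step at this place. The entering methoxy brings an oxygen and a hydrogen-bond acceptor that isopropyl lacks, but this single pair cannot separate these differences. No available evidence bears on the cause of this step. Still open, from the compounds shown here alone, is whether a dimethylamino or ethoxy group on the same carbonyl carbon keeps the number this low.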